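Methoxy position shift across two related cores

This account rests on a few compounds, and the source may have more. Where it says the series, first, only, none or still open, it means among the compounds named here.

Compound 1 `COc1cccc(/C=C/C(=O)c2ccc(OCCn3cc(CN4C(=O)/C=C/C(C)(C)C/C=C(\C)CC/C=C/4C)nn3)cc2O)c1` and compound 2 `COc1ccccc1/C=C/C(=O)c1ccc(OCCn2cc(CN3C(=O)/C=C/C(C)(C)C/C=C(\C)CC/C=C/3C)nn2)cc1O` share one core; in a functional assay on SW480 cells (Homo sapiens) for antiproliferative activity (a higher number here means a weaker inhibitor, a lower number a stronger inhibitor), compound 1 gives 0.95 ug/mL, and compound 2 gives 0.9 ug/mL. The change between them is 2-methoxyphenyl in place of 3-methoxyphenyl on a double-bonded chain carbon bound to a double-bonded chain carbon and the step is a 1.1-fold lower number from compound 1 to compound 2 (0.02 log units; within the scatter). Compound 3 `COc1cccc(/C=C/C(=O)c2ccc(OCCCN3C(=O)/C=C/C(C)(C)C/C=C(\C)CC/C=C/3C)cc2)c1` carries a different core; the difference between the cores of compound 1 and compound 3 is not broken down here. In this assay compound 3 gives 1.34 ug/mL, and its gaps to compound 1 and compound 2 both fall within the scatter. Compound 4 `COc1ccccc1/C=C/C(=O)c1ccc(OCCCN2C(=O)/C=C/C(C)(C)C/C=C(\C)CC/C=C/2C)cc1` is not yet measured; its difference from compound 3 is 2-methoxyphenyl in place of 3-methoxyphenyl on a double-bonded chain carbon bound to a double-bonded chain carbon, the same change as that between compound 1 and compound 2, at the same place. For compound 4 a small step is expected, a 1.1-fold lower number from compound 3 to compound 4 (0.05 log units; within the scatter), because of a 1.1-fold lower number from compound 1 to compound 2 (0.02 log units; within the scatter). Compound 4 is therefore estimated near 1.2 ug/mL, with a range from 0.6 ug/mL to 2.4 ug/mL.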

Compound 4, half-maximal inhibitory concentration: 1.33 ug/mL
Beside the measured number, compound 4's estimate is 1.1-fold (0.04 log units) below it; low and high end bracket the measured number.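

In this assay, 2-methoxyphenyl in place of 3-methoxyphenyl gives a 1.0-fold lower number from compound 3 to compound 4 (0.00 log units; within the scatter) on the core of compound 3. The change therefore reads the same on both cores: the same change on two cores in this assay, a 1.1-fold lower number (0.02 log units; within the scatter) from compound 1 to compound 2 and a 1.0-fold lower number (0.00 log units; within the scatter) from compound 3 to compound 4, 1.0-fold (0.02 log units) apart, within the scatter of two such steps
This shows that the two methoxyphenyl groups are not told apart on either core in this assay, but it shows no measurable effect that could be said to carry over, and it says nothing about other cores or other assays.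

The compounds shown leave open whether a group other than methoxy on this phenyl ring, such as a carboxylic acid or a dimethylamino group, would move the number on either core. They also leave open which part of the difference between the two cores matters, if any does.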